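Methyl on the fused ring of a methoxyphenyl analogue

The source may report more compounds than this note shows. Statements on the series, on what has been measured and on what is new or still open speak of the compounds shown alone.

Measured so far:
compound 1 `Cc1cnc2nc(-c3ccc(F)cc3)cc(O)c2c1`: 32400 nM
compound 2 `COc1ccc(-c2cc(O)c3cccnc3n2)cc1`: 56200 nM

Both compounds were tested in a functional assay on 786-0 cells (Homo sapiens); a higher number here means a weaker inhibitor of growth, a lower number a stronger inhibitor of growth. Compound 2 gives 56200 nM, and compound 1 with 32400 nM sits within the usual scatter of that number, so the two are not separated by this assay. Compound 2 differs from compound 1 both in the substituent on the pendant aryl ring and in the absence of the methyl on the fused system, so no single change can be read from these two alone.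

Compound 3 `COc1ccc(-c2cc(O)c3cc(C)cnc3n2)cc1` is the next member: methyl in place of hydrogen on an aromatic carbon. It carries the methyl that compound 1 also has, while keeping the methoxy aryl group of compound 2. Nothing measured here isolates this change, and the two numbers in hand lie within the scatter of each other, so a small step at most is expected, if any, with a slight lean toward a lower number. The expected step is a 1.4-fold lower number from compound 2 to compound 3 (0.15 log units; within the scatter). Compound 3 is estimated at 40000 nM, with a range from 15000 nM to 100000 nM.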

Compound 3, concentration for 50% growth inhibition: 5130 nM
Beside the measured number, compound 3's estimate is 7.8-fold (0.89 log units) above it; the whole stated range lies above it.
By their numbers in this assay, from the lowest: compound 3; then compounds 1 and 2 (each within the scatter of the next).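

In this assay, methyl in place of hydrogen on an aromatic carbon, two atoms from the ring nitrogen, gives an 11-fold lower number from compound 2 to compound 3 (1.04 log units; beyond the scatter) and so moves the number well beyond the scatter, which shows that this position is sensitive to the addition of a single carbon. With that methyl in place, the substituent on the other aryl ring also counts: methoxy in place of fluoro gives a 6.3-fold lower number from compound 1 to compound 3 (0.80 log units; beyond the scatter) as a modest step. Compound 1 and compound 2 could not show either effect, since they differ in two places at once and are not separated by this assay. No measurement here speaks to why the methyl has this effect.

As far as these compounds go, the methyl step is read only with methoxy on the aryl ring and the methoxy step only with the methyl present, so it remains open whether each holds without the other. From the compounds shown here alone, it is also open whether the gain is specific to methyl, or whether an ethyl, a chloro or an amine on the same aromatic carbon would give a comparable step.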